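The source may report more compounds than this note shows. Statements on the series, on what has been measured and on what is new or still open speak of the compounds shown alone.

In an assay on BTI-TN-5B1-4 cells for inhibition of Amine oxidase [flavin-containing] B (Homo sapiens), read by fluorescence and Amplex Red, using microsomes, with a stated time of 15 min (a lower number here means a stronger inhibitor, a higher number a weaker inhibitor), compound 1, `CC(C)c1ccc(NC(=O)OC2CCN(Cc3ccccc3)CC2)cc1`, is reported only as a limit, > 100000 nM. Compound 2, `C#CCN1CCC(COC(=O)N(C)CC)CC1`, likewise gives only a limit in this assay, > 100000 nM. Going by the values given here, both results sit at the limit of > 100000 nM in this assay, at which 2 of the 2 values shown sit, so no measured step stands between them. Compound 3, `CCN(C)C(=O)OCC1CCN(Cc2ccccc2)CC1`, differs from compound 2 by phenyl in place of ethynyl on a saturated chain carbon bound to an amine nitrogen in a ring. Among the compounds with values here, with compound 2 at the limit and no comparable step on record, the step that the limit leaves unreadable from compound 2 to compound 3 is expected to stay within the scatter. Compound 3 is therefore estimated at about 150000 nM, within 30000 nM to 1000000 nM, most probably once more reported only as a limit.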

Compound 3, half-maximal inhibitory concentration: > 100000 nM
Compound 3: no number, only a limit; the forecaster's own chance of this, stated with the estimate: 80%; the middle value lies beyond the limit too.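

Compound 3, like compound 2, is reported only as a limit, so no step can be read between these two compounds: the limit of > 100000 nM in this assay, at which 3 of the 3 values shown sit.

The compounds shown leave open whether phenyl and ethynyl differ at this place in this assay.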